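Swapping a Triazole for a Pyridine: Solubility Outlook

A few compounds are considered here, and "the series" means these few. Any claim that something is new, unique, unknown or untested is made for them only; others in the source may bear on it.

Compound 1 `Cc1cc(-n2nccn2)cc(C(=O)NNS(=O)(=O)c2ccccc2)c1F` carries a 2H-1,2,3-triazol-2-yl group on its ring of carbon only. Within the data shown here, in a physicochemical assay for solubility, read by nephelometry, in phosphate buffer, measured as kinetic solubility, at pH 6.5 (on this read-out higher numbers stand for higher solubility and lower numbers for lower solubility), compound 1 gives 25 ug/mL, the larger of the two numbers measured so far, though its distance to compound 2 lies within the scatter, so nothing separates them with confidence. Compound 2 `O=C(NNS(=O)(=O)c1ccccc1F)c1cccc(-c2ccccn2)c1`, built on a different core, gives 12.5 ug/mL in this assay. Compound 3 `Cc1cc(-c2ccccn2)cc(C(=O)NNS(=O)(=O)c2ccccc2)c1F` has not yet been measured. It differs from compound 1 in one place: pyridin-2-yl in place of 2H-1,2,3-triazol-2-yl on an aromatic carbon. Among the measured compounds shown here, no measured pair shows this change on its own, so its size must be judged indirectly. Compound 2, which also carries a pyridin-2-yl group, gives 12.5 ug/mL, a hint toward a somewhat lower value, although its core differs in several places. Compound 3 is therefore expected to give about 12 ug/mL, within a likely range from 5 ug/mL to 30 ug/mL, a step of a 2.1-fold lower number from compound 1 to compound 3 (0.32 log units; beyond the scatter) that is expected to sit near the edge of the scatter.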

Compound 3, solubility: 6.3 ug/mL
Compound 3: the middle estimate sits 1.9-fold (0.28 log units) above what was measured, within the range that was stated.
By their numbers in this assay, from the lowest: compounds 3, 2 and 1 (each within the scatter of the next, the first and the last beyond it).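

On the shared core, pyridin-2-yl in place of 2H-1,2,3-triazol-2-yl on the aromatic carbon can now be read directly: in this assay the change gives a 4.0-fold lower number from compound 1 to compound 3 (0.60 log units; beyond the scatter). Among these compounds, this is the first pair here that differs in one place only, so it shows that the group at this position, para to the fluoro group, can move the solubility reading by more than the usual scatter of the measurement. No measurement shown explains why the number falls with this swap.

One pair cannot separate the two differences between these groups, the size of the aromatic ring and its count of hetero atoms. On these data alone, what a morpholine or a carboxylic acid at this position would give in this assay remains open, as does whether the same swap would give a similar step on another core.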